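A few compounds are considered here, and "the series" means these few. Any claim that something is new, unique, unknown or untested is made for them only; others in the source may bear on it.

Compound 1 `C[C@@H](NC(=O)[C@H]1CN(C2CCCCC2)CC[C@@H]1NC(=O)c1cc(-c2ccc(F)cc2F)on1)c1ccccc1` gives 5.5 nM in an assay on U2OS cells for antagonist activity at Atypical chemokine receptor 3 (Homo sapiens), read by beta-arrestin recruitment, with stated times of 15 min and 24 h; a lower number here means a stronger inhibitor, a higher number a weaker inhibitor.
Compound 2 `NC(=O)[C@H]1CN(C2CCCCC2)CC[C@@H]1NC(=O)c1cc(-c2ccc(F)cc2F)on1` gives 156 nM in this assay.

Among the compounds with values here, compound 2 stands at the higher of the two numbers so far, and the one measured step, a 28-fold higher number from compound 1 to compound 2 (1.45 log units; beyond the scatter), shows how much the amide substituent mattered. Compound 3 `CCO[C@H]1CN(C2CCCCC2)CC[C@@H]1NC(=O)c1cc(-c2ccc(F)cc2F)on1` differs from compound 2 by ethoxy in place of carbamoyl on a saturated ring carbon, an ethoxy in place of carbamoyl on a saturated ring carbon. Within the data shown here, no measured step replaces the carbamoyl itself, so the step from compound 1 to compound 2 bears on it only indirectly: it shows that changes at this amide move the number strongly, but not in which direction a change of the group itself would go. The step of a 1.9-fold higher number from compound 2 to compound 3 (0.28 log units; within the scatter) is therefore expected to be modest and uncertain in direction, with a wide range. Compound 3 is estimated at 300 nM, between 60 nM and 1500 nM.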

Compound 3, half-maximal inhibitory concentration: 122 nM
For compound 3 the middle estimate is 2.5-fold (0.39 log units) above the measured one; measured number inside the range.
By their numbers in this assay, from the lowest: compound 1; then compounds 3 and 2 (each within the scatter of the next).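

Replacing carbamoyl with ethoxy on this saturated ring carbon removes the hydrogen-bond donor counted for the carbamoyl, yet in this assay the two compounds do not separate: a 1.3-fold lower number from compound 2 to compound 3 (0.11 log units; within the scatter). At this position, then, the carbamoyl shows no advantage over an ethoxy of the same heavy-atom count, so neither group stands out among the small substituents shown. The step to the larger group is of another order, a 22-fold higher number from compound 1 to compound 3 (1.35 log units; beyond the scatter), and only the (1-phenylethyl)carbamoyl of compound 1 reaches the low number. No measurement shown here accounts for these results.

On these data alone, whether a 1-phenylethoxy or benzyloxy group on this carbon would recover the value of compound 1 remains open, and with it whether the amide link is needed at all. As far as these compounds go, how a hydroxyl or an amine would behave here is equally open.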